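This account rests on a few compounds, and the source may have more. Where it says the series, first, only, none or still open, it means among the compounds named here.

Measured so far in a functional assay on NCI-H23 cells (Homo sapiens) for inhibition, read by sulforhodamine B assay, with a stated time of 48 h; on this read-out lower numbers stand for stronger inhibition of growth and higher numbers for weaker inhibition of growth:

compound 1 `N=C(N)c1ccc(-c2ccc(-c3ccc(F)cc3)o2)o1`, 1930 nM
compound 2 `N=C(N)c1ccc(-c2ccc(-c3ccc(Cl)cc3)o2)o1`, 1690 nM
compound 3 `N=C(N)c1ccc(-c2ccc(-c3ccc(Cl)cc3)s2)s1`, 1620 nM

Compound 2 and compound 1 share a core and differ only in one place, (fluoro in place of chloro on an aromatic carbon). In this assay this change made a 1.1-fold higher number from compound 2 to compound 1 (0.06 log units; within the scatter), so the two values sit together within the scatter. Compound 3 carries a different core from compound 2; the difference between the two cores is not broken down here. Its value in this assay and that of compound 2 also lie within the scatter of each other, so no order among the three measured compounds can be stated.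

Compound 4 `N=C(N)c1ccc(-c2ccc(-c3ccc(F)cc3)s2)s1` has not yet been measured in this assay. It differs from compound 3 by fluoro in place of chloro on an aromatic carbon, the same change as from compound 2 to compound 1. Resting on a 1.1-fold higher number from compound 2 to compound 1 (0.06 log units; within the scatter), the step from compound 3 to compound 4 is expected to be a 1.1-fold higher number from compound 3 to compound 4 (0.05 log units; within the scatter), again within the scatter. Compound 4 is therefore estimated at 1800 nM, with a likely range from 1000 nM to 3300 nM.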

Compound 4, concentration for 50% growth inhibition: 1800 nM
Compound 4: middle estimate and measured number agree at the digits printed; the measured number falls inside the stated range.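

In this assay the replacement of chloro by fluoro on an aromatic carbon gives a 1.1-fold higher number from compound 3 to compound 4 (0.05 log units; within the scatter) and so stays within the scatter. Set beside the same change on the other core, this step does not differ from the earlier one: the same change on two cores in this assay, a 1.1-fold higher number (0.06 log units; within the scatter) from compound 2 to compound 1 and a 1.1-fold higher number (0.05 log units; within the scatter) from compound 3 to compound 4, 1.0-fold (0.01 log units) apart, within the scatter of two such steps. Within the data shown here, the change therefore reads alike on these two cores, but both steps are so small that the agreement shows only that it leaves the number within the scatter on each core, not that a change with a larger step would carry across in the same way, and two cores are too few to support a rule for the whole series.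

The compounds shown leave open whether another group in this place, such as bromo, methoxy, an amine or a carboxylic acid, would move the number beyond the scatter. They also leave open whether any such step would then be the same on both cores.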